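A Methyl Group Added to Compound 2

A few compounds are considered here, and "the series" means these few. Any claim that something is new, unique, unknown or untested is made for them only; others in the source may bear on it.

For the measured compounds named here, in a functional assay on HL-60 cells (Homo sapiens) for activation, read by flow cytometry, with a stated time of 4 days (a higher number here means that more compound is needed for the effect, a lower number that less compound is needed), compound 2 (`COc1ccc(-n2cnc3cnc(-c4ccccc4)cc32)cc1OC`) gives 1600 nM, the only true number available. Compound 1 (`COc1ccc(-n2cnc3cnc(-c4cccc(NC(C)=O)c4)cc32)cc1OC`) gives > 30000 nM, which is a limit of the assay. Compound 3 (`COc1ccc(-n2cnc3cnc(-c4ccccc4C)cc32)cc1OC`) turns phenyl into 2-methylphenyl, with methyl in place of hydrogen, ortho to a large group: methyl in place of hydrogen on an aromatic carbon. Going by the values given here, only one measured step bears on this, the large at least 18-fold lower number from compound 1 to compound 2 (1.27 log units; beyond the scatter), and it concerns acetamido on that phenyl, not methyl. A much smaller rise is therefore expected, namely a 1.9-fold higher number from compound 2 to compound 3 (0.27 log units; within the scatter). Compound 3 is estimated at 3000 nM, with an expected range of 800 nM to 12000 nM.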

Compound 3, half-maximal effective concentration: 69 nM
Compound 3: the middle estimate sits 43-fold (1.64 log units) above what was measured; measured number outside the range, below it.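

In this assay, the phenyl of compound 2 responds strongly to one added methyl, ortho to a large group, with a 23-fold lower number from compound 2 to compound 3 (1.37 log units; beyond the scatter). The earlier step showed only that acetamido on this phenyl goes with a higher number, whereas here a group in place of hydrogen lowers the number, beyond the scatter. Nothing shown gives a reason for this step.

Whether this gain is particular to methyl remains open, since a larger group such as ethyl or a halogen such as chlorine is not among the compounds shown. As far as these compounds go, the effect of methyl on the other carbons of this ring also remains open.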